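A few compounds are considered here, and "the series" means these few. Any claim that something is new, unique, unknown or untested is made for them only; others in the source may bear on it.

Measured compounds:
In a functional assay on HCT-116 cells (Homo sapiens) for inhibition, read by MTT assay, with a stated time of 48 h (on this read-out lower numbers stand for stronger inhibition and higher numbers for weaker inhibition), compound 1 `CCOC(=O)CSc1nnc(-c2cc(OC)c(OC)c(OC)c2)n1-c1ccc(OC)cc1` gives only a limit, > 60000 nM.
Compound 2 `COc1ccc(NC(=O)CSc2nnc(-c3cc(OC)c(OC)c(OC)c3)n2-c2ccc(OC)cc2)cc1` likewise gives only a limit, > 60000 nM.
Compound 3 `CCOC(=O)CSc1nnc(-c2cc(OC)c(OC)c(OC)c2)n1-c1ccc(N(C)C)cc1` also gives only a limit, > 60000 nM.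

From compound 1 to compound 2 the change is (4-methoxyphenyl)amino in place of ethoxy on a carbonyl carbon; the step that the two limits leave unreadable from compound 1 to compound 2 cannot be sized, as all three values sit at the limit of > 60000 nM in this assay, at which 3 of the 3 values shown sit. The cores of compound 1 and compound 3 differ by dimethylamino in place of methoxy on an aromatic carbon, and a step that the two limits leave unreadable from compound 1 to compound 3 is equally unreadable. Compound 4 `COc1ccc(NC(=O)CSc2nnc(-c3cc(OC)c(OC)c(OC)c3)n2-c2ccc(N(C)C)cc2)cc1` carries (4-methoxyphenyl)amino in place of ethoxy on a carbonyl carbon, the same change on the same place as from compound 1 to compound 2. The step that the limit leaves unreadable from compound 3 to compound 4 is expected to be small in this assay, resting on compound 1 and compound 2 both standing at the limit of > 60000 nM in this assay, at which 3 of the 3 values shown sit, with a step that the two limits leave unreadable from compound 1 to compound 2. Compound 4 is estimated at 80000 nM, between 20000 nM and 300000 nM, most probably again only a limit.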

Compound 4, half-maximal inhibitory concentration: > 60000 nM
Compound 4 ended at the assay's limit (the forecaster's own chance of this, stated with the estimate: 85%); the middle value does not contradict the limit.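

No step can be read from compound 3 to compound 4 or from compound 2 to compound 4, as all these compounds give only a limit: the limit of > 60000 nM in this assay, at which 4 of the 4 values shown sit.

The compounds shown leave open what size of step either change produces on the shared core.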